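Inverting a saturated ring stereocentre: compound 3 to compound 4

The source may report more compounds than this note shows. Statements on the series, on what has been measured and on what is new or still open speak of the compounds shown alone.

compound 1 `CC(=O)N1CC[C@H](n2c(Nc3ccccc3)nc3cnc(Nc4ccc(N5CCN(C)CC5)cc4)nc32)C1` — "not determined" (no result reported)
compound 2 `CN1CCN(c2ccc(Nc3ncc4nc(Nc5ccccc5)n([C@@H]5CCNC5)c4n3)cc2)CC1` — "not determined" (no result reported)
compound 3 `CN1CCN(c2ccc(Nc3ncc4nc(Nc5ccccc5)n([C@H]5CCN(S(=O)(=O)C6CC6)C5)c4n3)cc2)CC1` — 240 nM

Among the compounds with values here, in a functional assay on NCI-H1975 cells (Homo sapiens) for antiproliferative activity, read by MTT assay, with a stated time of 72 h (on this read-out higher numbers stand for weaker inhibition and lower numbers for stronger inhibition), compound 3 gives 240 nM, the only number in the set; compound 1 and compound 2 carry no result. Compound 4 `CN1CCN(c2ccc(Nc3ncc4nc(Nc5ccccc5)n([C@@H]5CCN(S(=O)(=O)C6CC6)C5)c4n3)cc2)CC1` is the partner to compound 3: the two compounds have the same atoms and bonds and differ only in configuration as drawn: 1 of 1 stereo elements differ; a stereocentre at a saturated ring carbon is drawn S in compound 3 and R in compound 4. Within the data shown here, no pair of measured compounds separated by a single change exists, so the size of such a step cannot be read from these data. Nothing here sets the direction either, and the expectation for compound 4 is held loosely: a step beyond the scatter is plausible, with the wider room given to a loss. Compound 4 is estimated at 500 nM, range 100 nM to 3000 nM, an expected step of a 2.1-fold higher number from compound 3 to compound 4 (0.32 log units; beyond the scatter).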

Compound 4, half-maximal inhibitory concentration: 200 nM
Compound 4: middle estimate off by 2.5-fold (0.40 log units), on the high side; measured number inside the range.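

In this assay, inverting the stereocentre at the saturated ring carbon gives a 1.2-fold lower number from compound 3 to compound 4 (0.08 log units; within the scatter). Within the data shown here, this is the first readable step, and it shows that the S and R drawings cannot be told apart on this read-out when the ring nitrogen carries the cyclopropylsulfonyl group. The comparison speaks to configuration alone: the fact that compounds 3 and 4 differ only in the configuration as drawn.

Going by these compounds, whether the two configurations stay level with a longer alkylsulfonyl chain or a urea on that ring nitrogen remains open. Also open, on these data alone, is how much the sulfonyl group itself contributes to the activity.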